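A few compounds are considered here, and "the series" means these few. Any claim that something is new, unique, unknown or untested is made for them only; others in the source may bear on it.

Compound 1 `Cn1c(COc2cccc(C(=O)O)c2)nc2ccc(Oc3cccc(Cl)n3)cc21` gives 1.2. Compound 2 `Cc1ccnc(Oc2ccc3nc(COc4cccc(C(=O)O)c4)n(C)c3c2)c1` gives 0.8.

In a physicochemical assay for lipophilicity, read by LC-MS, in phosphate buffer, measured as octanol-water partition, with a stated time of 30 min, at pH 7.4, tested at 200 mM (on this read-out higher numbers stand for higher lipophilicity and lower numbers for lower lipophilicity), compound 2 stands lowest of the two numbers, with compound 1 sitting higher at 1.2. Compound 3 `Cn1c(COc2cccc(C(=O)O)c2)nc2ccc(Oc3ccc(F)cn3)cc21` differs from compound 2 by 5-fluoropyridin-2-yl in place of 4-methylpyridin-2-yl on an oxygen on an aromatic ring. Going by the values given here, only one measured step bears on this position: a number 0.40 log units lower from compound 1 to compound 2 (beyond the scatter), an exchange of the same ring on the same oxygen. That step settles the direction of the present exchange only loosely, but it shows that a swap of this ring moves the read-out modestly. Compound 3 is therefore expected to sit a little lower, by a number 0.30 log units lower from compound 2 to compound 3 (within the scatter), close to the scatter. Compound 3 is estimated at 0.5, between 0.1 and 0.9.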

Compound 3, distribution coefficient: 0.6
For compound 3 the middle estimate is 0.10 log units below the measured one, and the stated range covers the measured number.
By their numbers in this assay, from the lowest: compounds 3 and 2 (each within the scatter of the next); then compound 1.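

In this assay, the new ring gives a number 0.20 log units lower from compound 2 to compound 3 (within the scatter), so the 5-fluoropyridin-2-yl and 4-methylpyridin-2-yl groups cannot be told apart at this oxygen. The 6-chloropyridin-2-yl group stands apart from both, and the second exchange gives a number 0.60 log units lower from compound 1 to compound 3 (beyond the scatter), the largest step seen here at this position. Nothing measured here explains these steps.

Still open, as far as these compounds go, is whether a pyridin-2-yl ring carrying an amine or a longer chain would read with compound 2 and compound 3 or with compound 1.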